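Working notes: three limits and one untested analogue

The compounds below may be only part of what the source reports. "The series", "measured", "known", "first", "only" and "open" are said of these compounds alone.

Measured so far in an assay on CHO-K1 cells for inhibition of 11-beta-hydroxysteroid dehydrogenase type 2 (Homo sapiens), read by scintillation proximity assay; a lower number here means a stronger inhibitor, a higher number a weaker inhibitor:
Compound 1 `Cn1c(-c2ccccc2C(F)(F)F)nnc1C12CCC(CCS(C)(=O)=O)(CC1)CC2` gives > 4000 nM, a limit of the assay.
Compound 2 `CC(O)CCCC12CCC(c3nnc(-c4ccccc4C(F)(F)F)n3C)(CC1)CC2` gives > 1000 nM, a limit of the assay.
Compound 3 `Cn1c(-c2ccccc2C(F)(F)F)nnc1C12CCC(COc3ccc(S(C)(=O)=O)cc3)(CC1)CC2` gives > 4000 nM, a limit of the assay.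

Compound 3 therefore stands at a limit, and the two other values shown are limits as well, so no order among the three can be set; the limit of > 4000 nM in this assay, at which 2 of the 3 values shown sit, and the limit of > 1000 nM in this assay, at which 1 of the 3 values shown sits, are all the evidence in this assay.

The next compound is compound 4 `CC(F)CCCC12CCC(c3nnc(-c4ccccc4C(F)(F)F)n3C)(CC1)CC2`. Its change from compound 3 is 3-fluorobutyl in place of 4-(methylsulfonyl)phenoxy on a saturated chain carbon bound to a saturated ring carbon. The measured steps at the same place are a step that the two limits leave unreadable from compound 1 to compound 3 and a step that the two limits leave unreadable from compound 2 to compound 3, neither of which gives a readable size, since both ends of each sit at a limit. The 3-fluorobutyl chain of compound 4 differs from the 3-hydroxybutyl chain of compound 2 only in the fluorine against the hydroxyl, and compound 2 sits at a limit.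

On this basis compound 4 is expected to remain weak in this assay, most likely again reported as a limit. The estimate for compound 4 is 6000 nM, with a range from 1500 nM to 25000 nM. The expected step is a step that the limit leaves unreadable from compound 3 to compound 4, which cannot be read against a limit.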

Compound 4, half-maximal inhibitory concentration: 1300 nM
The estimate for compound 4 lay 4.6-fold (0.66 log units) above the measured number; the measured number lies below the stated range.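

Among these compounds, compound 4 is the first compound in this assay to give a number rather than a limit of the assay, so this place, a saturated chain carbon bound to a saturated ring carbon, now shows a readable change. 3-Fluorobutyl in place of 4-(methylsulfonyl)phenoxy gives an at least 3.0-fold lower number from compound 3 to compound 4 (0.48 log units; beyond the scatter), and 2-fluoropropyl in place of methylsulfonyl, two bonds along the chain from a saturated ring carbon, gives an at least 3.0-fold lower number from compound 1 to compound 4 (0.48 log units; beyond the scatter); each size is a minimum, as each step starts from a limit. The step with fluoro in place of hydroxy cannot be read, because compound 2 stands at a limit: the limit of > 1000 nM in this assay, at which 1 of the 4 values shown sits.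

The compounds shown leave open whether the fluorine itself contributes to the number for compound 4 or whether an unsubstituted butyl chain would read the same. Also open, on these data alone, are the full sizes of the two readable steps and how an amine or a carboxylic acid at the end of the chain would read in this assay.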